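The compounds below may be only part of what the source reports. "The series", "measured", "known", "first", "only" and "open" are said of these compounds alone.

Measured so far:
compound 1 `CCNC(=O)Nc1ccc(-c2nccc(C3=CCOCC3)n2)cc1`, 3.6
compound 2 `Oc1cccc(-c2nccc(C34CCOCC3C4)n2)c1`, 4.1

Both compounds were measured in a physicochemical assay for lipophilicity; on this read-out lower numbers stand for lower lipophilicity and higher numbers for higher lipophilicity. Compound 1 stands lowest of the two numbers; its nearest neighbour is compound 2, whose value in this assay lies higher by an amount beyond the usual scatter of repeated measurements. The two compounds differ in more than one place, so their gap is taken only for what the two values show. Compound 3 `CCNC(=O)Nc1ccc(-c2nccc(C34CCOCC3C4)n2)cc1` has not yet been measured in this assay. It differs from compound 1 in one place: a group of 7 heavy atoms (6 carbon, 1 oxygen; one three-membered non-aromatic ring of carbon only, one six-membered non-aromatic ring with 1 hetero atom) in place of a group of 6 heavy atoms (5 carbon, 1 oxygen; one six-membered non-aromatic ring with 1 hetero atom), on an aromatic carbon. For the measured compounds named here, no step between measured compounds matches this change, so the expectation rests on compound 1 alone. The change is expected to raise this read-out by a small step, roughly at the edge of the scatter. The expected step is a number 0.30 log units higher from compound 1 to compound 3 (within the scatter). Compound 3 is therefore expected to give 3.9, within 3.5 to 4.3.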

Compound 3, partition coefficient: 4
Estimate against measurement, compound 3: 0.10 log units below, and the stated range covers the measured number.
By their numbers in this assay, from the lowest: compound 1; then compounds 3 and 2 (each within the scatter of the next).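

In this assay, for the compounds shown here, the first single-place comparison at this position gives a number 0.40 log units higher from compound 1 to compound 3 (beyond the scatter) on the aromatic carbon next to the ring nitrogen. The earlier compounds shown here differed in more than one place and could not isolate this exchange, in which the group with a three-membered ring of carbon replaces the group with one double bond outside aromatic rings. The counts of hydrogen-bond donors and acceptors in the two groups are the same, and nothing shown gives a measured reason for the step.

From the compounds shown here alone, compound 2 carries the same entering group but has no partner with the leaving group, so the change rests on one pair of compounds and its size on other cores stays open. Going by these compounds, how an amine or a longer chain at this position would read in this assay also remains open.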